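Azido Replaces Hydroxy on the Shared Nucleotide Core

The source may hold more compounds than are shown below. What is called first, only, known or untested is meant among the compounds shown, and "the series" means these compounds.

In a functional assay on the whole organism for activation, with Mus musculus as the target, with stated times of 14 days and 2 h, at a dose of 30 mg/kg by the intravenous route (a lower number here means a weaker effect, a higher number a stronger effect of the compound at the dose given), compound 1 `CSc1nc2c(N)ncnc2n1[C@@H]1O[C@@H]2COP(=O)(O)O[C@H]2[C@H]1O` gives 804%, a strong effect in this whole-animal measurement. As far as these compounds go, compound 2 `Nc1ncnc2c1nc(O)n2[C@@H]1O[C@@H]2COP(=O)(O)O[C@H]2[C@H]1O` shares the same core but carries a hydroxy group on the five-membered ring; in this assay compound 2 gives no result reported, so no single number exists for it and its standing on this scale is unknown. Compound 3 `[N-]=[N+]=Nc1nc2c(N)ncnc2n1[C@@H]1O[C@@H]2COP(=O)(O)O[C@H]2[C@H]1O` differs from compound 2 in one place: azido in place of hydroxy on an aromatic carbon. Going by the values given here, with no measured value for compound 2, there is no fixed point from which to count the size of this step, and no step between measured compounds is available. Compound 1 shows that a non-hydroxy group at this place can give a very large read-out in this assay, but a single compound cannot show a pattern. Compound 3 is expected to give about 300%, with a likely range from 50% to 900%.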

Compound 3, a percentage reported as activity, at one dose (the size of the read-out at that dose, not a potency): 633%
Compound 3: middle estimate off by 333 percentage points, on the low side; the measured number falls inside the stated range.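

In this assay, replacing methylsulfanyl with azido on this aromatic carbon gives a number 171 percentage points lower from compound 1 to compound 3 (beyond the scatter) so the choice between these two groups clearly changes the size of the effect. Even so, compound 3 still reaches 633% in this whole-animal measurement, so a high read-out at this place does not belong to methylsulfanyl alone, though two compounds are too few to establish a pattern. Nothing available explains why azido gives the lower number of the two.

As far as these compounds go, with no number for compound 2, the step from hydroxy to azido cannot be read, so the effect of hydroxy at this place stays unknown. From the compounds shown here alone, it also remains open whether an amine, a bromine atom or a longer chain such as ethylsulfanyl would give a read-out closer to that of compound 1 or of compound 3.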